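The source may hold more compounds than are shown below. What is called first, only, known or untested is meant among the compounds shown, and "the series" means these compounds.

Measured compounds:
- compound 1, `COc1cc(/C=C/C(=O)/C=C/c2ccccc2)ccc1OCc1cn(CCCOc2cc(=O)oc3ccccc23)nn1`: "not active" (no number reported)
- compound 2, `COc1ccccc1/C=C/C(=O)/C=C/c1ccc(OCc2cn(CCOc3cc(=O)oc4ccccc34)nn2)c(OC)c1`: 11%
- compound 3, `COc1cc(/C=C/C(=O)/C=C/c2cc(OC)c(OC)c(OC)c2)ccc1OCc1cn(CCCCCOc2cc(=O)oc3ccccc23)nn1`: "not active" (no number reported)

All three were tested in a functional assay on PC-3 cells (Homo sapiens) for inhibition, read by sulforhodamine B assay, with a stated time of 48 h, tested at 50 uM; on this read-out higher numbers stand for more inhibition of growth at the one concentration tested and lower numbers for less inhibition of growth. Compound 3 stands without a single number there: in this assay compound 3 gives "not active" (no number reported), and the same holds for compound 1, which gives "not active" (no number reported). Only compound 2 has a number, giving 11% in this assay, a small value on this read-out. So the three measured compounds all sit at the weak end, and no step between two measured compounds that differ in one place is known.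

Compound 4, `COc1cc(/C=C/C(=O)/C=C/c2ccco2)ccc1OCc1cn(CCCCCOc2cc(=O)oc3ccccc23)nn1`, is the next compound. It differs from compound 3 in one place: furan-2-yl in place of 3,4,5-trimethoxyphenyl on a double-bonded chain carbon bound to a double-bonded chain carbon. Without any measured step to lean on, and with compound 3 not active, a change beyond the scatter in this assay is not expected in either direction; the result is likely to stay low, and a report with no number is quite possible. Compound 4 is expected to give about 10%, estimated between 0% and 25%.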

Compound 4, percent growth inhibition at one concentration: "not active" (no number reported)
Compound 4 has no reported number here, so the estimate cannot be set against anything.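

With compound 3 at "not active" (no number reported) and compound 4 at "not active" (no number reported) in this assay no step can be read between them. The compounds shown leave open whether furan-2-yl in place of 3,4,5-trimethoxyphenyl changes growth inhibition at all. No evidence at hand bears on this result.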